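Swapping Trifluoromethoxy for Hydroxypropyl on a Shared Core

A few compounds are considered here, and "the series" means these few. Any claim that something is new, unique, unknown or untested is made for them only; others in the source may bear on it.

Of the compounds shown here, three built on one shared core have been tested in an assay on isolated protein for inhibition of long-chain fatty acid transport protein 1 (Homo sapiens); a lower number here means a stronger inhibitor, a higher number a weaker inhibitor. Compound 1 `CCn1c(CNc2ccccc2)nnc1SCC(=O)Nc1ccc(OC)cc1` gives only a limit of that assay, > 1000 nM, so it supplies no exact number. Compound 2 `CCC(=O)c1ccc2oc(CS(=O)(=O)c3nnc(CNc4ccccc4)n3CC)nc2c1` gives 1670 nM. Compound 3 `CCn1c(CNc2ccccc2)nnc1SCc1nc2cc(OC(F)(F)F)ccc2o1` gives 100 nM, the lower of the two exact numbers and well apart from compound 2. Compound 4 `CCC(O)c1ccc2oc(CSc3nnc(CNc4ccccc4)n3CC)nc2c1` has not yet been tested. It differs from compound 3 in one place: 1-hydroxypropyl in place of trifluoromethoxy on an aromatic carbon. For the measured compounds named here, no measured pair isolates this change, so the expectation rests on judgement alone: the expected step is a loss of potency beyond the usual scatter, a 4.0-fold higher number from compound 3 to compound 4 (0.60 log units; beyond the scatter). Compound 4 is therefore estimated at 400 nM, within a range from 120 nM to 1500 nM.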

Compound 4, half-maximal inhibitory concentration: > 1000 nM
Compound 4 was reported as a limit (the forecaster's own chance of this, stated with the estimate: 20%); middle value at least 2.5-fold (0.39 log units) away from the limit.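

At this position, on the aromatic carbon, 1-hydroxypropyl in place of trifluoromethoxy gives an at least 10-fold higher number from compound 3 to compound 4 (1.00 log units; beyond the scatter). For the compounds shown here, this is the first single change measured here, and it shows that potency depends strongly on which group sits at this place on the shared core. The value of compound 4, > 1000 nM, is a limit and not a number, and it is not alone in this small set: the limit of > 1000 nM in this assay, at which 2 of the 4 values shown sit.

Only this one swap is shown, so it stays open whether the loss comes from removing trifluoromethoxy or from adding 1-hydroxypropyl. A plain propyl chain or an amine at this place could help separate the two.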